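Naphthyl to hydroxyphenyl on the amine of a shared core

The source may hold more compounds than are shown below. What is called first, only, known or untested is meant among the compounds shown, and "the series" means these compounds.

Measured compounds:
compound 1 `C=C1[C@@H](OC(C)=O)C[C@@H]2[C@](C)(COC=O)[C@H](OC(C)=O)CC[C@@]2(C)[C@@H]1C[C@@H](Nc1cccc2ccccc12)C1=CCOC1=O` 35600 nM
compound 2 `C=C1[C@@H](OC(C)=O)C[C@@H]2[C@](C)(CO[Si](C)(C)C(C)(C)C)[C@H](OC(C)=O)CC[C@@]2(C)[C@@H]1C[C@@H](Nc1cccc2ccccc12)C1=CCOC1=O` 4970 nM
compound 3 `C=C1[C@@H](OC(C)=O)C[C@@H]2[C@](C)(COC=O)[C@H](OC(C)=O)CC[C@@]2(C)[C@@H]1C/C=C1/C(=O)OC[C@H]1OC(C)=O` 19000 nM

In a functional assay on A549 cells (Homo sapiens) for cytotoxicity, read by sulforhodamine B assay (a higher number here means a weaker inhibitor, a lower number a stronger inhibitor), compound 1 gives 35600 nM, compound 2 gives 4970 nM and compound 3 gives 19000 nM. Among the measured compounds shown here, compound 2 has the lowest number of the three, with compound 3 nearer to it and compound 1 furthest; the one single-place step among them is a 7.2-fold lower number from compound 1 to compound 2 (0.86 log units; beyond the scatter). Compound 4 `C=C1[C@@H](OC(C)=O)C[C@@H]2[C@](C)(CO[Si](C)(C)C(C)(C)C)[C@H](OC(C)=O)CC[C@@]2(C)[C@@H]1C[C@@H](Nc1ccc(O)cc1)C1=CCOC1=O` is the next compound, differing from compound 2 only by 4-hydroxyphenyl in place of naphthalen-1-yl on an amine nitrogen. For the measured compounds named here, no measured step touches the group on the amine nitrogen, so nothing here points to a change beyond the scatter. Compound 4 is therefore expected near compound 2, with a 1.6-fold higher number from compound 2 to compound 4 (0.21 log units; within the scatter) as a guess, and an estimate of 8000 nM with a range from 2500 nM to 25000 nM.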

Compound 4, half-maximal inhibitory concentration: 5090 nM
Estimate against measurement, compound 4: 1.6-fold (0.20 log units) above, within the range that was stated.
By their numbers in this assay, from the lowest: compounds 2 and 4 (each within the scatter of the next); then compounds 3 and 1 (each within the scatter of the next).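

In this assay the amine nitrogen shows a 1.0-fold higher number from compound 2 to compound 4 (0.01 log units; within the scatter) as its first measured step, with 4-hydroxyphenyl in place of naphthalen-1-yl. The exchange removes one six-membered aromatic ring and adds a hydrogen-bond donor, yet the result stays within the scatter. No measured evidence accounts for this outcome.

As far as these compounds go, whether an unsubstituted phenyl, or an aminophenyl or carboxyphenyl group, would also stay within the scatter remains open. So does whether the same exchange would read alike on compound 1, which carries a different group on the shared core.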